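The compounds below may be only part of what the source reports. "The series", "measured", "known", "first", "only" and "open" are said of these compounds alone.

Series notes. In a functional assay on B16-F10 cells (Mus musculus) for inhibition, read by MTT assay, with a stated time of 72 h (on this read-out higher numbers stand for weaker inhibition and lower numbers for stronger inhibition), compound 1 `CC(C)c1ccc(-c2nc(SCc3cn(CC(=O)NC(=O)Nc4ccccn4)nn3)nc(Nc3ccccc3Cl)c2C#N)cc1` gives 6790 nM; compound 2 `CC(C)c1ccc(-c2nc(SCc3cn(CC(=O)NC(=O)Nc4ccccn4)nn3)nc(Nc3ccc(Cl)cc3)c2C#N)cc1` gives 860 nM and compound 3 `CC(C)c1ccc(-c2nc(SCc3cn(CC(=O)NC(=O)Nc4ccccn4)nn3)nc(Nc3cccc(C(F)(F)F)c3)c2C#N)cc1` gives 1700 nM. Compound 2 has the lowest number of the three: the step of a 7.9-fold lower number from compound 1 to compound 2 (0.90 log units; beyond the scatter) is beyond the scatter, while the step of a 2.0-fold higher number from compound 2 to compound 3 (0.30 log units; within the scatter) is within it. Compound 4 `CC(C)c1ccc(-c2nc(SCc3cn(CC(=O)NC(=O)Nc4ccccn4)nn3)nc(Nc3cccc([N+](=O)[O-])c3)c2C#N)cc1` is not yet measured; its change from compound 2 is 3-nitrophenyl in place of 4-chlorophenyl on a nitrogen on an aromatic ring. Among the compounds with values here, the measured steps on the same ring are a 7.9-fold lower number from compound 1 to compound 2 (0.90 log units; beyond the scatter), a 2.0-fold higher number from compound 2 to compound 3 (0.30 log units; within the scatter) and a 4.0-fold lower number from compound 1 to compound 3 (0.60 log units; beyond the scatter); no measured compound carries 3-nitrophenyl. For compound 4 the expected step is a 1.7-fold higher number from compound 2 to compound 4 (0.24 log units; within the scatter), which may stay within the scatter. The estimate for compound 4 is 1500 nM, ranging from 500 nM to 5000 nM.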

Compound 4, half-maximal inhibitory concentration: 26400 nM
Estimate against measurement, compound 4: 18-fold (1.25 log units) below; the measured number lies above the stated range.
By their numbers in this assay, from the lowest: compounds 2 and 3 (each within the scatter of the next); then compound 1; then compound 4.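

Nitro in place of trifluoromethyl on an aromatic carbon gives a 16-fold higher number from compound 3 to compound 4 (1.19 log units; beyond the scatter) in this assay, so the identity of the group matters here, whereas the two chlorophenyl compounds showed only the effect of where chlorine sits. With 3-nitrophenyl in place of 4-chlorophenyl the step is a 31-fold higher number from compound 2 to compound 4 (1.49 log units; beyond the scatter), and the number also passes that of the 2-chlorophenyl compound, with a 3.9-fold higher number from compound 1 to compound 4 (0.59 log units; beyond the scatter). Within the data shown here, nothing available bears on why this group shifts the number so far. From the compounds shown here alone, whether an amine or a carboxylic acid on the same phenyl ring would follow nitro or trifluoromethyl stays open. So does how 4-nitrophenyl would compare with 3-nitrophenyl.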